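Thiophen-2-yl in Place of Iodo: What Compound 4 May Give

The compounds below may be only part of what the source reports. "The series", "measured", "known", "first", "only" and "open" are said of these compounds alone.

Compound 1 `COc1nc(N)nc2c1c(-c1cc3ccccc3o1)cn2[C@@H]1O[C@H](CO)[C@@H](O)[C@H]1O` gives 14600 nM in a functional assay on K562 cells (Homo sapiens), read by MTT assay, with a stated time of 72 h; on this read-out higher numbers stand for weaker inhibition and lower numbers for stronger inhibition.
Compound 2 `Nc1nc(N)c2c(-c3cc4ccccc4o3)cn([C@@H]3O[C@H](CO)[C@@H](O)[C@H]3O)c2n1` gives 18600 nM in this assay.
Compound 3 `COc1ncnc2c1c(I)cn2[C@@H]1O[C@H](CO)[C@@H](O)[C@H]1O` gives > 20000 nM in this assay.

The value of compound 3 in this assay is a limit of the assay and not a number, as the evidence states (the limit of > 20000 nM in this assay, at which 1 of the 3 values shown sits). Compound 3 therefore stands at the weak end of what has been measured, with no number to place it more exactly. Compound 4 `COc1ncnc2c1c(-c1cccs1)cn2[C@@H]1O[C@H](CO)[C@@H](O)[C@H]1O` has not yet been measured in this assay; it differs from compound 3 by thiophen-2-yl in place of iodo on an aromatic carbon.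

Within the data shown here, the only measured step, a 1.3-fold higher number from compound 1 to compound 2 (0.11 log units; within the scatter), changes a group elsewhere on the core and so does not bear on this change. Compounds 1 and 2, which carry a larger aromatic group at the same place, both sit close to the limit at which compound 3 stands. Compound 4 is therefore expected to give a weak value in this assay, near the limit, with a step of an at least 1.1-fold lower number from compound 3 to compound 4 (0.04 log units; that floor lies within the scatter) estimated. The estimate for compound 4 is 18000 nM, between 8000 nM and 40000 nM, and a limit rather than a number remains quite possible.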

Compound 4, half-maximal inhibitory concentration: 70 nM
Compound 4: middle estimate off by 260-fold (2.41 log units), on the high side, outside the stated range (below it).
By their numbers in this assay, from the lowest: compound 4; then compounds 1 and 2 (each within the scatter of the next). At a limit, above all of these: compound 3.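

In this assay, thiophen-2-yl in place of iodo gives an at least 280-fold lower number from compound 3 to compound 4 (2.45 log units; beyond the scatter), so the group on this aromatic carbon, two ring bonds from the ring nitrogen, can shift the read-out far beyond the scatter. Among these compounds, the one earlier step changed a group elsewhere on the core and stayed within the scatter, so it showed nothing about this place. Compound 3 stands at a limit of the assay and not a number, which leaves the full size of the step unknown: the limit of > 20000 nM in this assay, at which 1 of the 4 values shown sits.

The compounds shown do not tell whether this shift needs the sulfur and the five-membered aromatic ring of thiophen-2-yl, or whether a phenyl or furan-2-yl group at the same place would also give it. On these data alone, it also remains open whether amino in place of methoxy, a step within the scatter on the core of compound 1, would stay so alongside thiophen-2-yl.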